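This account rests on a few compounds, and the source may have more. Where it says the series, first, only, none or still open, it means among the compounds named here.

Measured so far in an ADME assay on BJ cells (Homo sapiens) for cytotoxicity, with a stated time of 72 h; a higher number here means that more compound is needed for the effect, a lower number that less compound is needed:
compound 1 `Cc1cc(NC(=O)Nc2ccccc2N)c2ccccc2n1`: > 25000 nM
compound 2 `COC(=O)c1ccc(NC(=O)Nc2cc(C)nc3ccccc23)cc1`: 21000 nM
compound 3 `Cc1cc(NC(=O)Nc2cnc3ccccc3c2)c2ccccc2n1`: > 25000 nM

Compound 1 reaches only a limit of this assay, > 25000 nM. Compound 3 likewise stops at a limit, > 25000 nM. Compound 2 is the only one of the three with a number, 21000 nM, and that number sits close to the limit of > 25000 nM in this assay, at which 2 of the 3 values shown sit. Compound 4 `COc1ccc(NC(=O)Nc2cc(C)nc3ccccc23)cc1` differs from compound 2 by methoxy in place of methoxycarbonyl on an aromatic carbon. Among the measured compounds shown here, no step between measured compounds is available, so the size of this change in this assay is open; the expectation is that the step of a 1.1-fold higher number from compound 2 to compound 4 (0.06 log units; within the scatter) stays within the usual scatter, with compound 2 already near (the limit of > 25000 nM in this assay, at which 2 of the 3 values shown sit). Compound 4 is therefore expected at 24000 nM, between 10000 nM and 60000 nM, and may well be reported only as a limit.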

Compound 4, half-maximal effective concentration: > 25000 nM
Compound 4: only a limit was reported; the forecaster's own chance of this, stated with the estimate: 55%; at least 1.0-fold (0.01 log units) between middle value and limit.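

In this assay, among the compounds shown here, methoxy in place of methoxycarbonyl on the aromatic carbon gives the first readable step at this position: an at least 1.1-fold higher number from compound 2 to compound 4 (0.07 log units; that floor lies within the scatter). Compound 4 gives > 25000 nM, which is a limit. The change therefore has a floor but no size, and the series now sits even more heavily at one value: the limit of > 25000 nM in this assay, at which 3 of the 4 values shown sit.

From the compounds shown here alone, the true distance between compound 2 and compound 4 stays open. So does whether a carboxylic acid, an amine or a longer chain in this place would give a number clearly beyond the scatter.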